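An imidazole swap at the assay's limit

A few compounds are considered here, and "the series" means these few. Any claim that something is new, unique, unknown or untested is made for them only; others in the source may bear on it.

Compound 1 `Cn1cc(C2=C(c3nn(CCCn4cncn4)c4ncccc34)C(=O)NC2=O)c2ccccc21` gives > 100000 nM in a functional assay on ECa-109 cells (Homo sapiens) for antiproliferative activity, read by MTT assay, with a stated time of 48 h (on this read-out lower numbers stand for stronger inhibition and higher numbers for weaker inhibition), and that is a limit of the assay, not a number. Compound 2 `Cn1cc(C2=C(c3nn(CCCn4cncn4)c4ncccc34)C(=O)N(c3ccccc3)C2=O)c2ccccc21` gives > 100000 nM in this assay, which is again a limit. Compound 3 `Cn1cc(C2=C(c3nn(CCCN4CCCCC4)c4ncccc34)C(=O)N(c3ccc(Cl)cc3)C2=O)c2ccccc21` gives > 100000 nM in this assay, also a limit. Compound 2 therefore has no measured number of its own, and the evidence comes down to a single observation: the limit of > 100000 nM in this assay, at which 3 of the 3 values shown sit.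

Compound 4 `Cn1cc(C2=C(c3nn(CCCn4ccnc4)c4ncccc34)C(=O)N(c3ccccc3)C2=O)c2ccccc21` is compound 2 with one change in its side chain: 1H-imidazol-1-yl in place of 1H-1,2,4-triazol-1-yl on a saturated chain carbon, three bonds along the chain from an aromatic nitrogen. In words, 1H-imidazol-1-yl takes the place of 1H-1,2,4-triazol-1-yl on a saturated chain carbon, three bonds along the chain from an aromatic nitrogen.

Going by the values given here, the one measured step, a step that the two limits leave unreadable from compound 1 to compound 2, involves a different part of the molecule and has no size to carry over. No clear move in either direction is therefore expected in this assay, and another limit is the likeliest report. The estimated step is an at least 1.2-fold lower number from compound 2 to compound 4 (0.09 log units; that floor lies within the scatter), and it is measured against a limit rather than a number. For compound 4 the expected value is 80000 nM, with an estimated range from 20000 nM to 150000 nM.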

Compound 4, half-maximal inhibitory concentration: 1440 nM
For compound 4 the middle estimate is 56-fold (1.74 log units) above the measured one; measured number outside the range, below it.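

Going by these compounds alone, the place on a saturated chain carbon, three bonds along the chain from an aromatic nitrogen, is the first site here where a single change registers in this assay: 1H-imidazol-1-yl in place of 1H-1,2,4-triazol-1-yl gives an at least 69-fold lower number from compound 2 to compound 4 (1.84 log units; beyond the scatter). The two rings have the same number of heavy atoms, and the entering ring has one carbon where the leaving ring has a nitrogen and one hydrogen-bond acceptor fewer, yet this small exchange of atoms is enough to give compound 4 a real number, 1440 nM. The size of the step is only a floor, since compound 2 has no number of its own: the limit of > 100000 nM in this assay, at which 3 of the 4 values shown sit.

The compounds shown do not tell whether the gain seen with the 1H-imidazol-1-yl ring also holds with the amide hydrogen in place of the phenyl on the amide-type nitrogen. They also leave open how a 1H-pyrazol-1-yl ring, a dimethylamino group or a longer four-carbon chain would read in this assay.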